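This account rests on a few compounds, and the source may have more. Where it says the series, first, only, none or still open, it means among the compounds named here.

Of the compounds shown here, three built on one shared core have been measured in a functional assay on PC-3 cells (Homo sapiens) for inhibition, read by sulforhodamine B assay, with a stated time of 48 h; a lower number here means a stronger inhibitor of growth, a higher number a weaker inhibitor of growth. Compound 1 `COc1cc(-c2nn(-c3cccc(NC(=O)Nc4cc(C(F)(F)F)cc(C(F)(F)F)c4)c3)cc2-c2ccncc2)ccc1Cl` gives 250 nM and stands lowest of the three. Compound 3 `O=C(Nc1cccc(-n2cc(-c3ccncc3)c(-c3ccc(Cl)c(O)c3)n2)c1)Nc1ccc(Cl)c(Cl)c1` gives 834 nM, a number beyond the scatter above compound 1. Compound 2 `COc1cc(-c2nn(-c3cccc(NC(=O)c4cccc(C(F)(F)F)c4)c3)cc2-c2ccncc2)ccc1Cl` gives 1230 nM, the highest of the three and also beyond the scatter from compound 1. Among the compounds with values here, no two of these three differ in only one place, so no single step between measured compounds can be read off directly.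

Compound 4 `COc1cc(-c2nn(-c3cccc(NC(=O)Nc4cccc(C(F)(F)F)c4)c3)cc2-c2ccncc2)ccc1Cl` has not yet been measured. It differs from compound 1 in one place: hydrogen in place of trifluoromethyl on an aromatic carbon. Compound 2, which carries a single trifluoromethyl on that ring but an amide in place of the urea, gives a higher number than compound 1; compound 3, with a different pair of groups on that ring, gives a higher number as well. Taken together these two observations suggest that removing one trifluoromethyl is more likely to raise the number than to lower it. The step is therefore expected to be modest and toward a weaker inhibitor, with a 2.0-fold higher number from compound 1 to compound 4 (0.30 log units; within the scatter). Compound 4 is estimated at 500 nM, within a range from 200 nM to 1500 nM.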

Compound 4, concentration for 50% growth inhibition: 372 nM
Compound 4: middle estimate off by 1.3-fold (0.13 log units), on the high side, and the stated range covers the measured number.
By their numbers in this assay, from the lowest: compounds 1 and 4 (each within the scatter of the next); then compounds 3 and 2 (each within the scatter of the next).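

In this assay, hydrogen in place of trifluoromethyl on this aromatic carbon gives a 1.5-fold higher number from compound 1 to compound 4 (0.17 log units; within the scatter), so this assay does not tell compound 1 and compound 4 apart, and the second trifluoromethyl is not shown to be needed for the growth inhibition seen here. Within the data shown here, the other step gives the first direct reading of the link between the rings: with one trifluoromethyl kept on the ring, (3-(trifluoromethyl)phenyl)amino in place of 3-(trifluoromethyl)phenyl on a carbonyl carbon, which turns the amide into a urea, gives a 3.3-fold lower number from compound 2 to compound 4 (0.52 log units; beyond the scatter), and of these two changes only this one lies beyond the scatter. Nothing measured here explains either result.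

At this position only hydrogen and trifluoromethyl can be set side by side, so the compounds shown do not tell whether a methyl, a methoxy or an amine there would also leave the number within the scatter. As far as these compounds go, compound 3 differs from compound 4 in more than one place, so the separate contributions of its hydroxyl group and its two chlorines on the urea-bearing ring remain open.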